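Oxetan-3-yl for isopropyl on the aromatic oxygen

The source may report more compounds than this note shows. Statements on the series, on what has been measured and on what is new or still open speak of the compounds shown alone.

In a functional assay on MCF7 cells (Homo sapiens) for antiproliferative activity, read by MTT assay, with a stated time of 48 h (a higher number here means a weaker inhibitor, a lower number a stronger inhibitor), compound 3 `COc1cc(-c2nnc3c(OC(C)C)cc(-c4ccc5c(ccn5C)c4)cn23)cc(OC)c1OC` gives 204 nM and so lies within the scatter of compound 2 `CCOc1cc(-c2ccc3c(ccn3C)c2)cn2c(-c3cc(OC)c(OC)c(OC)c3)nnc12` at 140 nM and well under compound 1 `COc1cc(-c2nnc3c(OC4COC4)cc(-c4ccc5[nH]ccc5c4)cn23)cc(OC)c1OC` at 2470 nM on the same scale. The change to compound 4 `COc1cc(-c2nnc3c(OC4COC4)cc(-c4ccc5c(ccn5C)c4)cn23)cc(OC)c1OC` is oxetan-3-yl in place of isopropyl on an oxygen on an aromatic ring. Among the compounds with values here, the one measured step in this group is a 1.5-fold higher number from compound 2 to compound 3 (0.16 log units; within the scatter) and it brings in no ring. Within the data shown here, compound 1 carries the same oxetan-3-yl and gives 2470 nM but it differs elsewhere as well, and no measured pair isolates the oxetan-3-yl change. In this assay the expected step, a moderate rise in the number beyond the scatter, is a 2.5-fold higher number from compound 3 to compound 4 (0.41 log units; beyond the scatter) by this estimate. Compound 4 is expected at 520 nM (range 170 nM to 1600 nM).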

Compound 4, half-maximal inhibitory concentration: 1900 nM
Compound 4: the middle estimate sits 3.7-fold (0.56 log units) below what was measured, outside the stated range (above it).
By their numbers in this assay, from the lowest: compounds 2 and 3 (each within the scatter of the next); then compounds 4 and 1 (each within the scatter of the next).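

In this assay, the oxetan-3-yl on the aromatic oxygen now stands isolated as a change beyond the scatter against isopropyl (a 9.3-fold higher number from compound 3 to compound 4 (0.97 log units; beyond the scatter)) and against ethyl (a 14-fold higher number from compound 2 to compound 4 (1.13 log units; beyond the scatter)). Methyl in place of hydrogen on the aromatic nitrogen, by contrast, stays within the scatter with the oxetan-3-yl in place (a 1.3-fold lower number from compound 1 to compound 4 (0.11 log units; within the scatter)). No measurement at hand gives a cause for these steps.

Going by these compounds, whether the rise follows the ring or its oxygen stays open. So does how cyclobutyl, a 2-methoxyethyl chain or an amine-bearing chain would read on this oxygen.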